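The compounds below may be only part of what the source reports. "The series", "measured", "known", "first", "only" and "open" are said of these compounds alone.

Of the compounds shown here, two have so far been measured in a functional assay on the whole organism (Ear, strain Kunming) for inhibition, with Mus musculus as the target, with stated times of 1 h and 30 min, at a dose of 200 mg/kg by the oral route; a higher number here means more inhibition at the dose given (going by the name of the read-out), a lower number less inhibition. Compound 1 `Cc1ccc(N(C)CC2CCC/C(=C\c3ccccc3)C2=O)cc1` gives 18.3% in this assay, while compound 2 `Cc1ccc(/C=C2\CCCC(CN(C)c3ccccc3)C2=O)cc1` gives 39.5%. Compound 2 thus stands highest of the two numbers, and its nearest neighbour, compound 1, lies a distance below it that goes beyond the usual scatter of repeated runs. Among the measured compounds shown here, the two compounds differ in more than one place, so no single step can be drawn between them.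

Compound 3 `Cc1ccc(/C=C2\CCCC(CN(C)c3ccc(C)cc3)C2=O)cc1` has not yet been tested. It differs from compound 2 in one place: methyl in place of hydrogen on an aromatic carbon. Seen one bond further out, a phenyl becomes a 4-methylphenyl. For the measured compounds named here, no measured pair shows this change on its own, so the data give no size for it. Compound 3 is expected to give about 35% in this assay, with a range from 15% to 55%. The estimated step of a number 4.5 percentage points lower from compound 2 to compound 3 (within the scatter) is expected to fall within the usual scatter, with no clear direction beyond it.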

Compound 3, a percentage reported as inhibition, in the whole organism at one dose (the size of the read-out at that dose, not a potency): 27.6%
Estimate against measurement, compound 3: 7.4 percentage points above, and the stated range covers the measured number.
By their numbers in this assay, from the lowest: compounds 1 and 3 (each within the scatter of the next); then compound 2.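

In this assay, among the compounds shown here, the methyl on an aromatic carbon, para to a large group, gives the first step that can be read on its own: a number 11.9 percentage points lower from compound 2 to compound 3 (beyond the scatter) and so a modest loss rather than a gain at this position. For the compounds shown here, the same change of phenyl to 4-methylphenyl, made on the other aromatic ring, gives a number 9.3 percentage points higher from compound 1 to compound 3 (within the scatter) and so no step that can be told from scatter, which leaves only the first of these two steps beyond it. No measurement at hand gives a reason for the loss.

As far as these compounds go, it remains open whether a chlorine, a methoxy group or a longer chain such as ethyl at this same place would behave like the methyl. Equally open, from the compounds shown here alone, is what an amine or a carboxylic acid would do there.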